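This account rests on a few compounds, and the source may have more. Where it says the series, first, only, none or still open, it means among the compounds named here.

Compound 2 `CCCC(C)Oc1cccc2ccc(N)nc12` is one of three compounds tested in an assay on cells with melanin-concentrating hormone receptor 1 (Homo sapiens) as the target, read by radioligand binding (a lower number here means a stronger inhibitor, a higher number a weaker inhibitor), a series in which the shared core carries an ether substituent at one end and a nitrogen substituent at the other. In this assay compound 2 gives 105 nM. Compound 1 `Nc1ccc2cccc(OC3CCCCCC3)c2n1`, which carries a cycloheptyl group on the same oxygen, gives 137 nM in this assay, a number that sits within the usual scatter of the value for compound 2, so the two cannot be told apart. Compound 3 `CC(CC(C)(C)C)Oc1cccc2ccc(N3CCCC3)nc12`, in which the amino group is replaced by a pyrrolidinyl group, is reported only as a limit of the assay, > 2000 nM in this assay, and the limit of > 2000 nM in this assay, at which 1 of the 3 values shown sits, describes that limit rather than a number.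

Compound 4 `Nc1ccc2cccc(OCC3CCC3)c2n1` has not yet been measured in this assay. It differs from compound 2 in one place: cyclobutylmethyl in place of 1-methylbutyl on an oxygen on an aromatic ring. Both groups are small, saturated hydrocarbons of the same atom count, and compound 1 shows that a ring in this position is tolerated. The expected step from compound 2 to compound 4 in this assay is therefore a 1.4-fold higher number from compound 2 to compound 4 (0.15 log units; within the scatter), a change not beyond the scatter in either direction. For compound 4 the estimate in this assay is 150 nM, with a likely range from 50 nM to 450 nM.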

Compound 4, half-maximal inhibitory concentration: 432 nM
The estimate for compound 4 lay 2.9-fold (0.46 log units) below the measured number; the range from low to high includes it.
By their numbers in this assay, from the lowest: compounds 2 and 1 (each within the scatter of the next); then compound 4. At a limit, above all of these: compound 3.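

In this assay, the place on the oxygen separates two groups with the same count of carbon atoms: cyclobutylmethyl in place of 1-methylbutyl brings a 4.1-fold higher number from compound 2 to compound 4 (0.61 log units; beyond the scatter), so the count of heavy atoms alone does not set the number here. A ring as such does not go with the higher number, as compound 1 at 137 nM carries a cycloheptyl group on the same oxygen, so the shape of the group seems to matter more than the mere presence of a ring. Nothing among the data shown gives a reason for this step.

Still open, going by these compounds, is how a cyclopropylmethyl or cyclopentylmethyl group would read on this oxygen. Also open, on these data alone, is whether a longer chain, such as 1-methylpentyl, would keep the number of compound 2.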